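A few compounds are considered here, and "the series" means these few. Any claim that something is new, unique, unknown or untested is made for them only; others in the source may bear on it.

Measured in a functional assay on HCT-116 cells (Homo sapiens), read by MTT assay, with a stated time of 72 h; a lower number here means a stronger inhibitor, a higher number a weaker inhibitor:
Compound 1 `COc1nc(N)nc2c1c(-c1cccs1)cn2[C@@H]1O[C@H](CO)[C@@H](O)[C@H]1O`: > 20000 nM
Compound 2 `COc1nc(N)nc2c1c(-c1ccccc1)cn2[C@@H]1O[C@H](CO)[C@@H](O)[C@H]1O`: > 20000 nM

In this assay, compound 2 stands at > 20000 nM, which is a limit of the assay and not a number. The same holds for compound 1, so the evidence amounts to the limit of > 20000 nM in this assay, at which 2 of the 2 values shown sit. Compound 3 `C#Cc1cn([C@@H]2O[C@H](CO)[C@@H](O)[C@H]2O)c2nc(N)nc(OC)c12` has ethynyl in place of phenyl on an aromatic carbon.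

Within the data shown here, the only measured step bearing on this is a step that the two limits leave unreadable from compound 1 to compound 2. It replaced one aromatic ring with another and supplies no size, so neither the size nor the direction of the new step can be drawn from it. A move towards a lower number is tentatively expected, though compound 3 may well also report only a limit. The expected step is an at least 1.4-fold lower number from compound 2 to compound 3 (0.15 log units; that floor lies within the scatter). Compound 3 is estimated at 14000 nM, with an expected range from 3000 nM to 20000 nM.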

Compound 3, half-maximal inhibitory concentration: > 20000 nM
Compound 3 gave a limit, no number; the forecaster's own chance of this, stated with the estimate: 65%; at least 1.4-fold (0.15 log units) between middle value and limit.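

In this assay compound 3 gives > 20000 nM, a limit of the assay and not a number, so its steps from compound 1 and compound 2 cannot be read. The compounds shown leave open whether any group on that aromatic carbon changes the read-out.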